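This account rests on a few compounds, and the source may have more. Where it says the series, first, only, none or still open, it means among the compounds named here.

Measured in an assay on isolated protein for inhibition of alkaline phosphatase, tissue-nonspecific isozyme (Homo sapiens); on this read-out higher numbers stand for weaker inhibition and lower numbers for stronger inhibition:
compound 1 `COc1ccc(Cl)cc1S(=O)(=O)Nc1cncc(-c2ccncc2)c1` gives 73 nM
compound 2 `COc1ccc(Cl)cc1S(=O)(=O)Nc1cncc(C(N)=O)c1` gives 16 nM
compound 3 `COc1ccc(Cl)cc1S(=O)(=O)Nc1cncc(C(=O)O)c1` gives 134 nM

Compound 3 has the highest number of these three. Its nearest neighbour is compound 1, with a 1.8-fold higher number from compound 1 to compound 3 (0.26 log units; within the scatter), and its furthest is compound 2, with an 8.4-fold higher number from compound 2 to compound 3 (0.92 log units; beyond the scatter); in this assay a higher number stands for weaker inhibition, so compound 3 is at the weaker end of what has been measured.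

Compound 4 `COc1ccc(Cl)cc1S(=O)(=O)Nc1cncc(-c2ccc(Cl)cc2)c1` is not yet measured. It differs from compound 3 in one place: 4-chlorophenyl in place of carboxy on an aromatic carbon. The shared core and the sulfonamide part stay the same.

Within the data shown here, the step that bears most directly on this change is the one from compound 1 to compound 3, where a pyridin-4-yl ring gave way to carboxy: a 1.8-fold higher number from compound 1 to compound 3 (0.26 log units; within the scatter). Compound 4 goes the other way, from carboxy back to an aromatic ring, here a 4-chlorophenyl rather than a pyridin-4-yl. Among the measured compounds shown here, the only other step, a 4.6-fold lower number from compound 1 to compound 2 (0.66 log units; beyond the scatter), concerns carbamoyl and does not involve a ring. On this basis a number near that of compound 1 is expected for compound 4, that is a 2.2-fold lower number from compound 3 to compound 4 (0.35 log units; beyond the scatter), a step that may well stay within the scatter. The estimate for compound 4 in this assay is 60 nM, with a range from 18 nM to 200 nM.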

Compound 4, half-maximal inhibitory concentration: 198 nM
Compound 4: the middle estimate sits 3.3-fold (0.52 log units) below what was measured; the range from low to high includes it.
By their numbers in this assay, from the lowest: compound 2; then compounds 1, 3 and 4 (each within the scatter of the next, the first and the last beyond it).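

In this assay, the two aromatic rings at this position are not interchangeable: 4-chlorophenyl in place of pyridin-4-yl gives a 2.7-fold higher number from compound 1 to compound 4 (0.43 log units; beyond the scatter). Putting that same 4-chlorophenyl in place of carboxy, a group with no ring, makes no readable difference, with a 1.5-fold higher number from compound 3 to compound 4 (0.17 log units; within the scatter), so a ring of carbon only offers no advantage over carboxy on this read-out. Carbamoyl stays far ahead of 4-chlorophenyl, with a 12-fold higher number from compound 2 to compound 4 (1.09 log units; beyond the scatter), and the carbamoyl compound remains the strongest inhibitor of the four, with its steps to each of the others beyond the scatter.

Nothing available explains why these groups differ. Also open, going by these compounds, is whether the chlorine on the ring contributes anything, which a plain phenyl would test, and whether the advantage of carbamoyl survives in close relatives such as an N-methyl amide or a nitrile, or extends to a small amine at the same place.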